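The source may hold more compounds than are shown below. What is called first, only, known or untested is meant among the compounds shown, and "the series" means these compounds.

Series notes. Within the data shown here, compound 3 `Cc1nnc(CN(C)C)n1-c1ccc(Cl)cc1C(=O)c1ccccc1Cl` gives 0.14 mg/kg in a functional assay on the whole organism (strain CF-1) for inhibition, with Mus musculus as the target (on this read-out higher numbers stand for an effect only at larger amounts of compound and lower numbers for an effect already at smaller amounts), the lowest of the three numbers so far. Compound 1 `Cc1nnc(CN(C)C)n1-c1ccc(Cl)cc1C(=O)c1ccccc1` gives 0.5 mg/kg in this assay, and compound 2 `CN(C)Cc1nnc(-c2ccncc2)n1-c1ccc(Cl)cc1C(=O)c1ccccc1Cl` gives 11 mg/kg. The step of a 3.6-fold lower number from compound 1 to compound 3 (0.55 log units; beyond the scatter) and the step of a 79-fold lower number from compound 2 to compound 3 (1.90 log units; beyond the scatter) set compound 3 apart from both. Compound 4 `CN(C)Cc1nnc(C2CC2)n1-c1ccc(Cl)cc1C(=O)c1ccccc1Cl` is not yet measured; it differs from compound 3 by cyclopropyl in place of methyl on an aromatic carbon, the site between two ring nitrogen atoms. Among the measured compounds shown here, the one measured step that touches this site is a 79-fold lower number from compound 2 to compound 3 (1.90 log units; beyond the scatter), where an aromatic group was exchanged for methyl. Cyclopropyl is a three-membered non-aromatic ring of carbon only, not an aromatic group, so a far smaller rise than that step is expected, a 2.1-fold higher number from compound 3 to compound 4 (0.33 log units; beyond the scatter). Compound 4 is estimated at 0.3 mg/kg in this assay, within a range of 0.1 mg/kg to 1 mg/kg.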

Compound 4, dose for half-maximal effect: 0.6 mg/kg
For compound 4 the middle estimate is 2.0-fold (0.30 log units) below the measured one; the measured number falls inside the stated range.
By their numbers in this assay, from the lowest: compound 3; then compounds 1 and 4 (each within the scatter of the next); then compound 2.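

At the site between two ring nitrogen atoms, methyl remains the better of the three groups in this assay, and cyclopropyl gives up only part of its advantage, with a 4.3-fold higher number from compound 3 to compound 4 (0.63 log units; beyond the scatter). Most of the penalty seen with pyridin-4-yl is absent from the non-aromatic ring, with an 18-fold lower number from compound 2 to compound 4 (1.26 log units; beyond the scatter). No measured evidence accounts for either step.

On these data alone, whether an ethyl chain would track cyclopropyl, or a phenyl group would track pyridin-4-yl, remains open. So does whether the cyclopropyl step holds with hydrogen in place of the chloro on the benzoyl ring of compound 4.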